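Lengthening the Sulfonyl Chain: Propyl to Hexyl

The source may hold more compounds than are shown below. What is called first, only, known or untested is meant among the compounds shown, and "the series" means these compounds.

Compound 1, `CCS(=O)(=O)c1nnc(COc2cc(C)c3c(C)cc(=O)oc3c2)o1`, gives in a functional assay on MDA-MB-231 cells (Homo sapiens) for antiproliferative activity, read by MTT assay, with a stated time of 24 h (on this read-out higher numbers stand for weaker inhibition and lower numbers for stronger inhibition), only a limit, > 100000 nM.
Compound 2, `CCCS(=O)(=O)c1nnc(COc2cc(C)c3c(C)cc(=O)oc3c2)o1`, gives in this assay 7070 nM.

Within the data shown here, compound 2 holds the only number measured so far in this assay; the other value shown is a limit. Among the measured compounds shown here, the one measured step, an at least 14-fold lower number from compound 1 to compound 2 (1.15 log units; beyond the scatter), is a chain extension of the same sulfonyl substituent, and its true size is known only as a minimum because compound 1 sits at the limit of > 100000 nM in this assay, at which 1 of the 2 values shown sits.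

Compound 3, `CCCCCCS(=O)(=O)c1nnc(COc2cc(C)c3c(C)cc(=O)oc3c2)o1`, carries the change (propyl in place of hydrogen on a saturated chain carbon, three bonds along the chain from a sulfonyl sulfur). The step from compound 1 to compound 2 is the only one that bears on it, since both lengthen the chain on the sulfonyl sulfur, and it was large. Whether the gain continues at the same rate over three further carbons cannot be read from one step, so a smaller further lowering is expected. Compound 3 is therefore estimated at 2500 nM, with a range from 500 nM to 15000 nM, which means an expected step of a 2.8-fold lower number from compound 2 to compound 3 (0.45 log units; beyond the scatter).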

Compound 3, half-maximal inhibitory concentration: > 100000 nM
Compound 3: no number, only a limit; the forecaster's own chance of this, stated with the estimate: 10%; middle value at least 40-fold (1.60 log units) from the limit.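

The sulfonyl chain does not keep paying off as it grows: in this assay, the change from propyl to hexyl runs against the earlier gain, with an at least 14-fold higher number from compound 2 to compound 3 (1.15 log units; beyond the scatter). Among the ethyl, propyl and hexyl chains shown, only the propyl chain of compound 2 gives a measured number, so the response to chain length is not a steady trend in either direction. Compound 3 gives only a limit, > 100000 nM. The rise to compound 3 is therefore known only as a minimum, and the step between compound 1 and compound 3 cannot be read, since both sit at a limit: the limit of > 100000 nM in this assay, at which 2 of the 3 values shown sit.

The compounds shown leave open how butyl or pentyl on the sulfonyl sulfur would compare with the propyl chain of compound 2, and so where between propyl and hexyl the loss sets in. They also leave open whether a branched chain such as isopropyl, or a chain ending in an amine or a carboxylic acid, would follow the plain chains in this assay.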